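The source may hold more compounds than are shown below. What is called first, only, known or untested is meant among the compounds shown, and "the series" means these compounds.

Measured so far:
- compound 1, `CSc1cnc2ccccc2c1[Se]CC#CCOC(=O)c1ccc(C(=O)O)cc1`: 19.1 ug/mL
- compound 2, `ClCC#CCSc1cnc2ccccc2c1Cl`: 13.4 ug/mL
- compound 3, `CSc1cnc2ccccc2c1[Se]CC#CCO`: 2.6 ug/mL

These three compounds were tested in a functional assay on P388 cells (Mus musculus) for antiproliferative activity, with a stated time of 72 h; on this read-out lower numbers stand for stronger inhibition and higher numbers for weaker inhibition. Compound 3 holds the lowest number of the three, so on this read-out it is the strongest inhibitor; its gap to compound 2 and its larger gap to compound 1 both lie beyond the usual scatter of repeated measurements.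

The next compound, compound 4, `CSc1cnc2ccccc2c1[Se]CC#CCOC(=O)c1ccccc1`, differs from compound 3 in one place: benzoyl in place of hydrogen on an oxygen on a saturated carbon. Among the measured compounds shown here, no step between two measured compounds matches this change, so the expectation must rest on the values themselves. Compound 1 is the measured compound that most resembles compound 4, and in this assay compound 1 gives 19.1 ug/mL, a far higher number than compound 3. On that basis a weakening step is expected, from compound 3 to compound 4, of about a 3.1-fold higher number from compound 3 to compound 4 (0.49 log units; beyond the scatter), though smaller than the gap between compound 3 and compound 1. Compound 4 is therefore estimated to give about 8 ug/mL, with a range from 3 ug/mL to 20 ug/mL.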

Compound 4, concentration for 50% inhibition: 3.5 ug/mL
Beside the measured number, compound 4's estimate is 2.3-fold (0.36 log units) above it, within the range that was stated.
By their numbers in this assay, from the lowest: compounds 3 and 4 (each within the scatter of the next); then compounds 2 and 1 (each within the scatter of the next).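

In this assay, benzoyl in place of hydrogen on this oxygen gives a 1.3-fold higher number from compound 3 to compound 4 (0.13 log units; within the scatter), so adding this whole group at this position produces no change that can be told from the scatter. The large number of compound 1 therefore does not follow from the benzoyl ester alone: hydrogen in place of carboxy on an aromatic carbon gives a 5.5-fold lower number from compound 1 to compound 4 (0.74 log units; beyond the scatter), which ties the difference to the carboxy group on that ring. Nothing measured here explains why either step has the size it does.

Going by these compounds, it remains open whether a smaller acetyl group or a longer alkyl chain on this oxygen would also leave the number unchanged. On these data alone, it is equally open whether an amine or a methoxy group in place of carboxy on the aromatic carbon would behave like hydrogen or like carboxy.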